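A Linker Change Measured by Lipophilicity

A few compounds are considered here, and "the series" means these few. Any claim that something is new, unique, unknown or untested is made for them only; others in the source may bear on it.

This account follows three measured compounds and a fourth not yet measured. Compound 1 `CC(=O)Nc1ccc(OC(=S)Nc2ccc(Nc3ccc([N+](=O)[O-])cc3)cc2)cc1` gives 4.32 in a physicochemical assay for lipophilicity; a lower number here means a more polar compound, a higher number a more lipophilic compound. Compound 2 `O=[N+]([O-])c1ccc(Sc2ccc(NC(=S)Oc3ccc(O)cc3)cc2)cc1` gives 5.25 in this assay, and compound 3 `Oc1ccc(OC(=S)Nc2ccc(Nc3ccc(C(F)(F)F)cc3)cc2)cc1` gives 6.04. Compound 1 therefore stands lowest of the three numbers: compound 2 lies nearest, with a number that is higher beyond the scatter, and compound 3 lies furthest, higher still and also beyond the scatter. No pair among these three differs in a single place, so no step between measured compounds is available to lean on.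

Compound 4 `CC(=O)Nc1ccc(OC(=S)Nc2ccc(Oc3ccc([N+](=O)[O-])cc3)cc2)cc1` differs from compound 1 in one place: 4-nitrophenoxy in place of (4-nitrophenyl)amino on an aromatic carbon. The group that leaves carries one hydrogen-bond donor; the group that enters carries none.

Among the compounds with values here, with no measured step for this exact change, the size of the step is expected from the numbers of compound 1 and from the nature of the change. Compound 4 is expected to come out higher than compound 1 in this assay, by a step of a number 0.58 log units higher from compound 1 to compound 4 (beyond the scatter), beyond the scatter but modest. The estimate for compound 4 in this assay is 4.9, with a range from 4.4 to 5.4.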

Compound 4, partition coefficient: 4.81
Compound 4: the middle estimate sits 0.09 log units above what was measured; the range from low to high includes it.
By their numbers in this assay, from the lowest: compound 1; then compound 4; then compound 2; then compound 3.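

The pair of compound 1 and compound 4 gives this account its first step that can be read at a single place: with 4-nitrophenoxy in place of (4-nitrophenyl)amino on an aromatic carbon, this assay shows a number 0.49 log units higher from compound 1 to compound 4 (beyond the scatter), and that step is modest. Within the data shown here, the two groups match in heavy-atom count and in hydrogen-bond acceptors, while the hydrogen-bond donor of the group that leaves has no counterpart in the group that enters, so this modest step goes with a change of one linking atom and the loss of that donor. Nothing measured here bears on what lies behind the step.

This single pair cannot show whether the same replacement gives a step of like size when the nitro group gives way to another group, such as a nitrile or a carboxylic acid. It also leaves open where a compound would fall in this assay if a methylene or a carbonyl took the place of the linking atom in compound 1.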